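Adding a Second Chloro Group to a Shifted Core

The compounds below may be only part of what the source reports. "The series", "measured", "known", "first", "only" and "open" are said of these compounds alone.

Four compounds share a bicyclic sulfone core carrying an aryl-amino substituent, and they are compared in a functional assay on MDA-MB-231 cells (Homo sapiens) for antiproliferative activity, read by MTT assay, with a stated time of 72 h; a higher number here means a weaker inhibitor, a lower number a stronger inhibitor. Compound 1 `O=S1(=O)C=Cc2ccc(Nc3ccc(Cl)cc3)cc21` gives 6720 nM in this assay. Compound 2 `O=S1(=O)C=Cc2ccc(Nc3ccc(Cl)c(Cl)c3)cc21` differs from compound 1 by one change, (chloro in place of hydrogen on an aromatic carbon), and compound 2 gives 890 nM in this assay. That change produced a 7.6-fold lower number from compound 1 to compound 2 (0.88 log units; beyond the scatter).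

Compound 3 `O=S1(=O)C=Cc2cccc(Nc3ccc(Cl)cc3)c21` carries the same atoms as compound 1 joined differently; the difference between the two cores is not broken down here. In this assay compound 3 gives 1210 nM, a lower number than compound 1 shows, while compound 2 and compound 3 lie within the usual scatter of each other.

Compound 4 `O=S1(=O)C=Cc2cccc(Nc3ccc(Cl)c(Cl)c3)c21` has not yet been measured. It differs from compound 3 by chloro in place of hydrogen on an aromatic carbon, the same change that separates compound 1 from compound 2, made at a place described in the same words. On the core of compound 1 this change gave a 7.6-fold lower number from compound 1 to compound 2 (0.88 log units; beyond the scatter), and only that single example of it exists among these compounds. Because compound 3 sits at 1210 nM and the same change is applied, a step of similar direction is expected, though its size on the shifted core is uncertain. The expected step is a 4.8-fold lower number from compound 3 to compound 4 (0.68 log units; beyond the scatter). For compound 4 the estimated value in this assay is 250 nM, with a plausible range from 80 nM to 900 nM.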

Compound 4, half-maximal inhibitory concentration: 1360 nM
The estimate for compound 4 lay 5.4-fold (0.74 log units) below the measured number; measured number above the stated range.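

In this assay, adding the second chloro group to the shifted core gives a 1.1-fold higher number from compound 3 to compound 4 (0.05 log units; within the scatter), so compound 3 and compound 4 cannot be told apart and this core shows no gain from the change. A step measured on one core therefore did not predict the step on the other in this series, and the two cores respond differently to the same swap of hydrogen for chloro: the same change on two cores in this assay, a 7.6-fold lower number (0.88 log units; beyond the scatter) from compound 1 to compound 2 and a 1.1-fold higher number (0.05 log units; within the scatter) from compound 3 to compound 4, 8.5-fold (0.93 log units) apart, beyond the scatter of two such steps. This rests on a single pair of compounds for each core, so it shows that the change does not always carry over, but it does not show why the cores differ, nor how often such a mismatch would appear with other changes in this series.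

Going by these compounds, it remains open whether other groups at the same place on the aromatic ring, such as a methyl group, a methoxy group, a nitrile or a carboxylic acid, would also split the two cores or would act alike on both. A further open question is whether a group other than chloro could lower the number on the core of compound 3 at all.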